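The compounds below may be only part of what the source reports. "The series", "measured", "known", "first", "only" and "open" are said of these compounds alone.

Measured compounds:
- compound 1, `CCCCCCCCCCCCNc1ccc(O)cc1`: 13%
- compound 2, `CCCCCCCCCCCC(=O)Nc1ccc(O)cc1`: 22%

Both were tested in a functional assay on HepG2 cells (Homo sapiens) for inhibition, with a stated time of 68 h, tested at 4 uM; a lower number here means less inhibition, a higher number more inhibition at the concentration tested (going by the name of the read-out). The gap between compound 1 and compound 2 is within the scatter, so no order between them is claimed.

Compound 3, `CCCCCCCCCC(=O)Nc1ccc(O)cc1`, awaits measurement in this assay. Compared with compound 2 the change is hydrogen in place of ethyl on a saturated chain carbon, nine bonds along the chain from a carbonyl carbon. Among the compounds with values here, no measured step of this kind is available, and the two values at hand give no direction. The step from compound 2 to compound 3 is therefore expected to stay within the scatter, a number 4 percentage points lower from compound 2 to compound 3 (within the scatter). Compound 3 is estimated at 18%, in the range 5% to 32%.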

Compound 3, a percentage reported as inhibition, at one concentration (the size of the read-out at that concentration, not a potency): 26%
Compound 3: middle estimate off by 8 percentage points, on the low side, and the stated range covers the measured number.
By their numbers in this assay, from the lowest: compounds 1, 2 and 3 (each within the scatter of the next, the first and the last beyond it).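

In this assay, within the data shown here, hydrogen in place of ethyl on a saturated chain carbon, nine bonds along the chain from a carbonyl carbon, gives a number 4 percentage points higher from compound 2 to compound 3 (within the scatter) as the first measured step at this position. At this one position, then, removing the ethyl does not separate the two compounds, and no order between them is claimed. Nothing available bears on the reason for this result.
Still open, as far as these compounds go, is whether a longer chain would separate from compound 2 beyond the scatter. Also open, from the compounds shown here alone, is what a carboxylic acid or an amine at the chain end would do.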